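Amide variation on the shared core: hydroxyazetidine amide

A few compounds are considered here, and "the series" means these few. Any claim that something is new, unique, unknown or untested is made for them only; others in the source may bear on it.

Measured so far:
compound 1, `COc1cc(-n2cccc2C(=O)N2CCCCC2)ccc1Nc1ncc(Cl)c(Nc2ccccc2NS(C)(=O)=O)n1`, 630 nM
compound 2, `COc1cc(-n2cccc2C(=O)N2CCCC2)ccc1Nc1ncc(Cl)c(Nc2ccccc2NS(C)(=O)=O)n1`, 600 nM
compound 3, `COc1cc(-n2cccc2C(=O)NCCO)ccc1Nc1ncc(Cl)c(Nc2ccccc2NS(C)(=O)=O)n1`, 34 nM

In a functional assay on NCI-H2228 cells (Homo sapiens) for antiproliferative activity, read by MTT assay, with a stated time of 72 h (a higher number here means a weaker inhibitor, a lower number a stronger inhibitor), compound 1 gives the highest of the three numbers. Its nearest neighbour is compound 2, and the step of a 1.1-fold lower number from compound 1 to compound 2 (0.02 log units; within the scatter) lies within the scatter, so the two cyclic amides cannot be ranked. The furthest is compound 3, where the step of a 19-fold lower number from compound 1 to compound 3 (1.27 log units; beyond the scatter) is large, as is the parallel step an 18-fold lower number from compound 2 to compound 3 (1.25 log units; beyond the scatter): opening the cyclic amide to an open-chain amide carrying a hydroxyl lowers the number markedly in both comparisons.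

Compound 4, `COc1cc(-n2cccc2C(=O)N2CC(O)C2)ccc1Nc1ncc(Cl)c(Nc2ccccc2NS(C)(=O)=O)n1`, is not yet measured. It differs from compound 1 as follows: 3-hydroxyazetidin-1-yl in place of piperidin-1-yl on a carbonyl carbon. The new group keeps a cyclic amide, as in compound 1 and compound 2, but brings in a hydroxyl donor and acceptor, the feature compound 3 carries. The step from compound 1 to compound 3 bears most directly; the step from compound 1 to compound 2 shows that ring size alone does little. A step downward beyond the scatter is therefore expected, though probably smaller than that to compound 3 because a 19-fold lower number from compound 1 to compound 3 (1.27 log units; beyond the scatter) came with an open chain rather than a ring. Compound 4 is expected to give 90 nM, with a range of 30 nM to 280 nM. The expected step is a 7.0-fold lower number from compound 1 to compound 4 (0.85 log units; beyond the scatter).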

Compound 4, half-maximal inhibitory concentration: 44 nM
For compound 4 the middle estimate is 2.0-fold (0.31 log units) above the measured one; low and high end bracket the measured number.
By their numbers in this assay, from the lowest: compounds 3 and 4 (each within the scatter of the next); then compounds 2 and 1 (each within the scatter of the next).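

In this assay, the 3-hydroxyazetidin-1-yl amide gives a 14-fold lower number from compound 1 to compound 4 (1.16 log units; beyond the scatter) and a 14-fold lower number from compound 2 to compound 4 (1.13 log units; beyond the scatter), so a ring on this carbonyl carbon does not in itself go with the high numbers of the piperidin-1-yl and pyrrolidin-1-yl amides. With a 1.3-fold higher number from compound 3 to compound 4 (0.11 log units; within the scatter), within the scatter, compound 3 and compound 4 cannot be ranked; among the four compounds, the two amides carrying a hydroxyl, compound 3 and compound 4, stand apart from the two without one, compound 1 and compound 2, and no compound shown goes against this split. No evidence is at hand to explain this split.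

In compound 4 the hydroxyl and the four-membered ring enter together, so their shares in the step cannot be separated: the unsubstituted azetidin-1-yl amide and the 4-hydroxypiperidin-1-yl amide would address this from either side. Also open, going by these compounds, is whether the hydroxyl itself matters at this place or whether another group would serve there, such as the methoxy of a 3-methoxyazetidin-1-yl amide or the amine of a 3-aminoazetidin-1-yl amide.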